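The compounds below may be only part of what the source reports. "The series", "measured", "known", "first", "only" and "open" are said of these compounds alone.

Measured compounds:
- compound 1, `Nc1nc(-c2cccc(F)c2)nc2sc(Cc3ccccc3)cc12`: 123 nM
- compound 2, `Nc1nc(-c2cnccn2)nc2sc(Cc3ccccc3)cc12`: 91 nM

In a functional assay on CHO-K1 cells for antagonist activity at adenosine receptor A1 (Homo sapiens), read by a beta-galactosidase reporter and cAMP accumulation, with stated times of 15 min and 6 h (a lower number here means a stronger inhibitor, a higher number a weaker inhibitor), compound 1 gives 123 nM and compound 2 gives 91 nM. Compound 2 carries the lower of the two numbers, but the step of a 1.4-fold lower number from compound 1 to compound 2 (0.13 log units; within the scatter) lies within the scatter, so the two values cannot be ordered on this evidence. Compound 2 and compound 1 differ only in the aryl group carried by the shared core, with pyrazin-2-yl in place of 3-fluorophenyl on an aromatic carbon.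

Compound 3, `Nc1nc(-c2ncccn2)nc2sc(Cc3ccccc3)cc12`, has not yet been measured in this assay. It differs from compound 2 by pyrimidin-2-yl in place of pyrazin-2-yl on an aromatic carbon. Within the data shown here, the one measured step that bears on this position is the exchange from compound 1 to compound 2, a swap of the whole aryl group, which stayed within the scatter. Moving a ring nitrogen within the same six-membered heteroaryl is a smaller change than that swap, so no step beyond the scatter is expected here, in either direction. Compound 3 is therefore estimated at 100 nM, within a range of 40 nM to 250 nM, which means an expected step of a 1.1-fold higher number from compound 2 to compound 3 (0.04 log units; within the scatter).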

Compound 3, inhibition constant: 618 nM
Compound 3: middle estimate off by 6.2-fold (0.79 log units), on the low side; the measured number lies above the stated range.
By their numbers in this assay, from the lowest: compounds 2 and 1 (each within the scatter of the next); then compound 3.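

In this assay this position proves sensitive to where the ring nitrogens lie: pyrimidin-2-yl in place of pyrazin-2-yl gives a 6.8-fold higher number from compound 2 to compound 3 (0.83 log units; beyond the scatter) even though both groups have the same heavy atoms, ring size and counted hydrogen-bond acceptors. Against 3-fluorophenyl the two groups also part company, since pyrazin-2-yl gives a 1.4-fold lower number from compound 1 to compound 2 (0.13 log units; within the scatter) while pyrimidin-2-yl gives a 5.0-fold higher number from compound 1 to compound 3 (0.70 log units; beyond the scatter) and so the presence of two ring nitrogens does not alone set the outcome among these compounds. Nothing available here accounts for the difference between the two isomeric groups.

As far as these compounds go, three aryl groups cannot show whether the loss in compound 3 goes with the pyrimidin-2-yl arrangement specifically, so the standing of pyridin-2-yl, pyrimidin-4-yl and pyrimidin-5-yl at this position remains open. From the compounds shown here alone, it is also open whether the gap between the pyrazin-2-yl and pyrimidin-2-yl groups would persist if a small substituent such as a methyl group or an amine were carried on these rings.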